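Swapping the cinnamoyl aryl: from trimethoxy to fluorine

The source may hold more compounds than are shown below. What is called first, only, known or untested is meant among the compounds shown, and "the series" means these compounds.

Three cinnamanilides have been tested in a functional assay on HeLa cells (Homo sapiens) for cytotoxicity, read by MTT assay, with a stated time of 72 h; on this read-out lower numbers stand for stronger inhibition and higher numbers for weaker inhibition. The smallest, compound 1 `COc1cccc(/C=C/C(=O)Nc2cc(OC)c(OC)c(OC)c2)c1`, carries no ketone bridge and gives 12300 nM. Adding a trimethoxybenzoyl group to the aniline ring yields compound 2 `COc1ccc(C(=O)c2cc(OC)c(OC)c(OC)c2)cc1NC(=O)/C=C/c1cc(OC)c(OC)c(OC)c1`, which gives 1500 nM, and a further methoxy on that ring yields compound 3 `COc1cc(C(=O)c2cc(OC)c(OC)c(OC)c2)cc(NC(=O)/C=C/c2cc(OC)c(OC)c(OC)c2)c1OC`, which gives 2500 nM. Compound 3 therefore holds the second highest of the three numbers: its value sits within the scatter of compound 2, as the step of a 1.7-fold higher number from compound 2 to compound 3 (0.22 log units; within the scatter) shows, while compound 1 stands clearly apart with a higher number.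

Compound 4 `COc1cc(C(=O)c2cc(OC)c(OC)c(OC)c2)cc(NC(=O)/C=C/c2ccc(F)cc2)c1OC` keeps the whole core of compound 3 and differs only at the far end of the cinnamoyl chain: 4-fluorophenyl in place of 3,4,5-trimethoxyphenyl on a double-bonded chain carbon bound to a double-bonded chain carbon. Going by the values given here, none of the measured steps touches this part of the molecule; the only step recorded, from compound 2 to compound 3, concerns a methoxy on the aniline ring and is small. Among the compounds with values here, there is thus no direct precedent, and the change is a large one in size and acceptor count.

For compound 4 a weakening is expected, with the step of a 2.4-fold higher number from compound 3 to compound 4 (0.38 log units; beyond the scatter), giving an estimated 6000 nM and a range from 1500 nM to 25000 nM.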

Compound 4, half-maximal inhibitory concentration: 900 nM
For compound 4 the middle estimate is 6.7-fold (0.82 log units) above the measured one; the whole stated range lies above it.
By their numbers in this assay, from the lowest: compounds 4, 2 and 3 (each within the scatter of the next, the first and the last beyond it); then compound 1.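

In this assay, the far end of the cinnamoyl chain tolerates a large change: with the rest of compound 3 held fixed, the step of a 2.8-fold lower number from compound 3 to compound 4 (0.44 log units; beyond the scatter) is a modest gain and not a loss. The 3,4,5-trimethoxyphenyl group, with 12 heavy atoms and 3 hydrogen-bond acceptors, is therefore not required at this place on this core, and 4-fluorophenyl, with 7 heavy atoms and 0 hydrogen-bond acceptors, does better there. No measurement offered here accounts for the shift, so the step stands as an observation without an explanation.

The swap alters the size of the group and its acceptor count together, and it also brings in fluorine, so the compounds shown cannot separate these changes; plain phenyl, 4-chlorophenyl or 4-methoxyphenyl at this place would help pull them apart. Also open, on these data alone, are whether the same swap would give a similar step on the core of compound 2, and whether a group of another kind on this ring, such as an amine or a carboxylic acid, would be tolerated.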